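From hydroxy to piperidin-1-yl on a chain at the limit

A few compounds are considered here, and "the series" means these few. Any claim that something is new, unique, unknown or untested is made for them only; others in the source may bear on it.

In a functional assay on K562 cells (Homo sapiens) for antiproliferative activity, read by MTT assay, with a stated time of 48 h (a lower number here means a stronger inhibitor, a higher number a weaker inhibitor), compound 1 (`Cn1c(N)c(-c2nc3ccccc3[nH]2)c2nc(C#N)c(C#N)nc21`) gives > 50000 nM as a limit. Compound 2 (`N#Cc1nc2c(-c3nc4ccccc4[nH]3)c(N)n(CCCO)c2nc1C#N`), with its 3-hydroxypropyl chain, likewise gives > 50000 nM as a limit and no number. Compound 3 (`N#Cc1nc2c(-c3nc4ccccc4[nH]3)c(N)n(CCCN3CCCCC3)c2nc1C#N`) ends that chain in piperidin-1-yl in place of hydroxy. piperidin-1-yl in place of hydroxy on a saturated chain carbon, three bonds along the chain from an aromatic nitrogen is the whole change. Within the data shown here, the one measured step is a step that the two limits leave unreadable from compound 1 to compound 2 and so sets no size to carry over. A modest strengthening is expected all the same, and the estimated change is an at least 2.5-fold lower number from compound 2 to compound 3 (0.39 log units; beyond the scatter) in this assay on this reading. Compound 3 is estimated at 20000 nM within an expected range from 5000 nM to 50000 nM as a cautious guess.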

Compound 3, half-maximal inhibitory concentration: 3460 nM
Estimate against measurement, compound 3: 5.8-fold (0.76 log units) above; measured number outside the range, below it.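

In this assay, ending the chain in piperidin-1-yl in place of hydroxy gives an at least 14-fold lower number from compound 2 to compound 3 (1.15 log units; beyond the scatter), and the whole chain gives an at least 14-fold lower number from compound 1 to compound 3 (1.15 log units; beyond the scatter). Compound 2, which carries the same chain ending in hydroxy, stays at the limit of > 50000 nM, so at this position it is the chain end that brings a measurable number; the step from compound 1 to compound 2 cannot be read. From the compounds shown here alone, the full size of both readable steps stays open: the limit of > 50000 nM in this assay, at which 2 of the 3 values shown sit. Going by these compounds, whether a morpholin-4-yl or dimethylamino end, or a shorter chain carrying piperidin-1-yl, would act alike also remains open.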